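A few compounds are considered here, and "the series" means these few. Any claim that something is new, unique, unknown or untested is made for them only; others in the source may bear on it.

Compound 1 `COc1cc(/C=C/C(=O)c2sc(Nc3ccc(Cl)cc3)nc2C)cc(OC)c1OC`: 22000 nM.
Compound 2 `Cc1nc(Nc2ccc(Cl)c(Cl)c2)sc1C(=O)/C=C/c1ccc(Cl)cc1`: > 25000 nM, a limit.

In a functional assay on NCI-H460 cells (Homo sapiens) for cytotoxicity, read by MTT assay (a higher number here means a weaker inhibitor, a lower number a stronger inhibitor), compound 1 gives 22000 nM, the only number shown. Compound 2 sits at the limit of > 25000 nM in this assay, at which 1 of the 2 values shown sits, which is a limit of the assay and not a number. Compound 3 `COc1cc(/C=C/C(=O)c2sc(Nc3cccc(C)c3)nc2C)cc(OC)c1OC` differs from compound 1 by 3-methylphenyl in place of 4-chlorophenyl on a nitrogen on an aromatic ring, read one bond further out as (4-chlorophenyl)amino to (3-methylphenyl)amino. For the measured compounds named here, no step between measured compounds is available, so the expected step from compound 1 to compound 3 in this assay, a 1.1-fold lower number from compound 1 to compound 3 (0.04 log units; within the scatter), is taken as no larger than the scatter and without a clear direction. Compound 3 is estimated at 20000 nM, within 7000 nM to 60000 nM.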

Compound 3, half-maximal inhibitory concentration: 19800 nM
Compound 3: middle estimate off by 1.0-fold (0.00 log units), on the high side, within the range that was stated.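

In this assay, the exchange on the nitrogen on an aromatic ring gives a 1.1-fold lower number from compound 1 to compound 3 (0.05 log units; within the scatter), so 3-methylphenyl and 4-chlorophenyl cannot be told apart here. Compound 1 alone could not show that a methyl group at the 3-position of the phenyl ring and a chlorine at its 4-position would read alike. Nothing measured here explains this result. Still open, going by these compounds, is whether any group on this nitrogen separates from these two: a phenyl ring carrying a carboxylic acid or an amine, or a longer alkyl chain in place of the ring.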